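Methyl for methoxy on the benzyl group of compound 3

The compounds below may be only part of what the source reports. "The series", "measured", "known", "first", "only" and "open" are said of these compounds alone.

Values in a functional assay on HepG2 cells (Homo sapiens) for inhibition, read by MTT assay, with a stated time of 48 h (on this read-out higher numbers stand for weaker inhibition and lower numbers for stronger inhibition), are as follows.
- compound 1 `COc1ccc(-n2c(SCc3ccc(C)cc3)nnc2-c2cc(OC)c(OC)c(OC)c2)cc1` gives 31600 nM
- compound 2 `COc1cc(-c2nnc(S)n2-c2ccc(N(C)C)cc2)cc(OC)c1OC` gives a limit (> 60000 nM)
- compound 3 `COc1ccc(CSc2nnc(-c3cc(OC)c(OC)c(OC)c3)n2-c2ccc(N(C)C)cc2)cc1` gives a limit (> 60000 nM)

For compound 3 only a limit is known (> 60000 nM), so it has no number of its own.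

Compound 4 `COc1cc(-c2nnc(SCc3ccc(C)cc3)n2-c2ccc(N(C)C)cc2)cc(OC)c1OC` differs from it by methyl in place of methoxy on an aromatic carbon, para to a large group, turning 4-methoxybenzyl into 4-methylbenzyl (methyl in place of methoxy on an aromatic carbon).

Among the compounds with values here, the only measured step touching compound 3 is a step that the two limits leave unreadable from compound 2 to compound 3, with 4-methoxybenzyl in place of hydrogen on a sulfur, and it offers no size to carry over. Compound 1 also carries the 4-methylbenzyl group and has a number (31600 nM), which is the sole hint that stronger inhibition is possible. A modest shift towards stronger inhibition in this assay is therefore expected, with a further limit quite possible. The expected step is an at least 1.2-fold lower number from compound 3 to compound 4 (0.07 log units; that floor lies within the scatter) and remains loosely defined. For compound 4 the estimate is 50000 nM (expected range 20000 nM to 120000 nM).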

Compound 4, half-maximal inhibitory concentration: > 60000 nM
Compound 4 ended at the assay's limit (the forecaster's own chance of this, stated with the estimate: 55%); at least 1.2-fold (0.07 log units) between middle value and limit.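

In this assay compound 4 gives > 60000 nM, which is a limit and not a number. Methyl in place of methoxy on the benzyl group therefore gives no readable value at this position, and the steps linking compound 2, compound 3 and compound 4 cannot be read, because all three sit at the same limit: the limit of > 60000 nM in this assay, at which 3 of the 4 values shown sit. Within the data shown here, with 4-methylbenzyl held constant, a change from methoxy to dimethylamino gives an at least 1.8-fold higher number from compound 1 to compound 4 (0.27 log units; that floor lies within the scatter), so the only step with any readable size lies at that other place, and its floor does not go beyond the scatter.

From the compounds shown here alone, the size of the methoxy to methyl change remains unknown. Also open, going by these compounds, is whether an amine or a carboxylic acid on the benzyl group, or a longer chain on the sulfur, would give a readable number alongside dimethylamino.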